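The source may hold more compounds than are shown below. What is called first, only, known or untested is meant among the compounds shown, and "the series" means these compounds.

Working notes on a small set tested in a functional assay on PC-3 cells (Homo sapiens) for antiproliferative activity, read by MTT assay, tested at 1 uM; a lower number here means a weaker effect, a higher number a stronger effect of the compound at the concentration tested. Going by the values given here, compound 1 `COc1ccc(OC)c(C2OC(c3cc(OC)c(OC)c(OC)c3)=NN2C(C)=O)c1` gives 37.2% in this assay, the highest of the three numbers measured so far. Compound 2 `COc1ccc(OC)c(/C=N/NC(=O)c2cc(OC)c(OC)c(OC)c2)c1` gives 30.9% in this assay, a number that sits within the scatter of the value for compound 1. Compound 3 `COc1cc(C(=O)N/N=C/c2cc(Cl)cc(Cl)c2)cc(OC)c1OC` gives 22.1% in this assay, which lies beyond the scatter below compound 1. Among the compounds with values here, compound 3 is the only measured compound whose second aryl group carries no hydrogen-bond acceptors, and its number is the lowest of the set; with a single example this is an observation, not a pattern.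

The unmeasured compound 4 `COc1cc(C2=NN(C(C)=O)C(c3cccc(C(F)(F)F)c3)O2)cc(OC)c1OC` keeps the core of compound 1 and differs from it in one place: 3-(trifluoromethyl)phenyl in place of 2,5-dimethoxyphenyl on a saturated ring carbon. Within the data shown here, no pair of measured compounds shares this exact change, so the size of the step cannot be read from the data. The step from compound 1 to compound 4 is expected to be a number 9.2 percentage points lower from compound 1 to compound 4 (within the scatter), a modest fall. The low value of compound 3, 22.1%, is the only hint that an acceptor-free aryl group may sit lower. Compound 4 is therefore expected to give about 28% in this assay, within a range from 14% to 42%.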

Compound 4, a percentage reported as inhibition, at one concentration (the size of the read-out at that concentration, not a potency): 30.1%
Beside the measured number, compound 4's estimate is 2.1 percentage points below it; the range from low to high includes it.
By their numbers in this assay, from the lowest: compounds 3, 4, 2 and 1 (each within the scatter of the next, the first and the last beyond it).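

In this assay, going by these compounds alone, 3-(trifluoromethyl)phenyl in place of 2,5-dimethoxyphenyl on a saturated ring carbon gives a number 7.1 percentage points lower from compound 1 to compound 4 (within the scatter), the first step in the set that can be read at a single place on the shared core. At this place, then, an aryl group with no hydrogen-bond acceptors replaces one that carries them without a step beyond the scatter, so this pair gives no support to the idea that such acceptors are needed here, although one pair cannot settle the point for other aryl groups. No measurement offered here explains the size of this step or what the exchange changes in the cells.

From the compounds shown here alone, it remains open whether this ring carbon accepts a substituent of another kind, such as a phenyl ring carrying a carboxylic acid or a dimethylamino group, or a simple methyl group in place of the aryl ring. Going by these compounds, the role of the acetyl group on the core is also open, as is whether a longer chain in its place would leave the number within the scatter of the value for compound 1.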